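The compounds below may be only part of what the source reports. "The series", "measured", "known", "first", "only" and "open" are said of these compounds alone.

Measured in a functional assay on MCF7 cells (Homo sapiens) for inhibition, read by MTT assay, with a stated time of 24 h; on this read-out higher numbers stand for weaker inhibition and lower numbers for stronger inhibition:

Compound 1 `O=C(Cn1c(=O)c(/C=C\c2ccncc2)nc2ccccc21)Nc1ccc(Cl)cc1` gives > 100000 nM, which is a limit of the assay and not a number.
Compound 2 `Cc1ccccc1NC(=O)Cn1c(=O)c(/C=C\c2ccncc2)nc2ccccc21` gives > 100000 nM, again a limit of the assay.
Compound 3 `Cc1ccc(NC(=O)COc2nc3ccccc3nc2C)cc1` gives > 100000 nM, also a limit of the assay.

Compound 3 therefore stands at the edge of what this assay can report, not at a measured point; the same holds for every value shown, as the limit of > 100000 nM in this assay, at which 3 of the 3 values shown sit, states. Within the data shown here, the only step between measured compounds that differ in one place, a step that the two limits leave unreadable from compound 1 to compound 2, cannot be read in size or direction, since both of its ends are limits. Among the measured compounds shown here, no measured step bears directly on the change now considered.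

Compound 4 `Cc1nc2ccccc2nc1OCC(=O)Nc1ccc(Cl)cc1` differs from compound 3 by chloro in place of methyl on an aromatic carbon. Compound 1 carries a 4-chlorophenyl on a different core and sits at the limit too, which gives no measured guidance either way.

With three limits and no readable step, compound 4 is expected to give a similar limit in this assay, so the expected step of a number no higher from compound 3 to compound 4 (the limit leaves the size open) is none beyond the scatter. The estimate for compound 4 is 100000 nM, within a range from 30000 nM to 300000 nM.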

Compound 4, half-maximal inhibitory concentration: > 100000 nM
Compound 4 ended at the assay's limit (the forecaster's own chance of this, stated with the estimate: 85%); the middle value sits exactly at the limit.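

Compound 3 and compound 4 both end at a limit, so no step between them can be read, in size or in direction: the limit of > 100000 nM in this assay, at which 4 of the 4 values shown sit.

The compounds shown leave open what structure would give an actual number in this assay, and how chloro and methyl compare there.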